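The source may hold more compounds than are shown below. What is called first, only, known or untested is meant among the compounds shown, and "the series" means these compounds.

In a physicochemical assay for lipophilicity, at pH 7.4 (a lower number here means a more polar compound, a higher number a more lipophilic compound), compound 1 `CNC(=O)c1cc(C(=O)N[C@H]2[C@@H]3C[C@H](O)C[C@@H]32)cc2c1OC[C@@]2(C)c1ccccc1` gives 3.7. For the measured compounds named here, compound 3 `CNC(=O)c1cc(C(=O)NC2CC2)cc2c1OC[C@H]2c1cccc(F)c1` gives 3.7, level with compound 1 within the usual scatter of such measurements, and together they hold the highest of the three numbers known so far. Compound 2 `CNC(=O)c1cc(C(=O)N[C@H]2[C@@H]3COC[C@@H]32)cc2c1OC[C@H]2c1ccncc1` gives 1.3, a gap beyond the scatter from the other two. No two of these three compounds differ in one place only, so they offer no clean single-change comparison.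

Compound 4 `CNC(=O)c1cc(C(=O)N[C@H]2[C@@H]3C[C@@H](O)C[C@@H]32)cc2c1OC[C@@]2(C)c1ccccc1` is a very close relative of compound 1. The two have the same atoms and bonds and differ only in configuration as drawn, meaning the three-dimensional arrangement at one point: the two compounds have the same atoms and bonds and differ only in configuration as drawn: 1 of 5 stereo elements differ; a stereocentre at a saturated ring carbon is drawn S in compound 1 and R in compound 4. Here a stereocentre at a saturated ring carbon is drawn S in compound 1 and R in compound 4. Going by the values given here, nothing enters or leaves, but the data hold no measured example of this kind of change, so its size remains a judgement. Starting from compound 1 at 3.7, no change beyond the scatter is expected in this assay, and no direction is favoured. The estimated step of no change at the digits printed from compound 1 to compound 4 (within the scatter) is therefore expected to stay within the scatter. Compound 4 is estimated at 3.7, with an expected range from 3.3 to 4.1.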

Compound 4, distribution coefficient: 3.3
Compound 4: the middle estimate sits 0.40 log units above what was measured; the range from low to high includes it.
By their numbers in this assay, from the lowest: compound 2; then compound 4; then compounds 1 and 3 (each within the scatter of the next).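

The set now holds its first clean single-change comparison: in this assay, turning a stereocentre at a saturated ring carbon from S to R gives a number 0.40 log units lower from compound 1 to compound 4 (beyond the scatter). The earlier compounds shown here could not show this, since each differs from the others in more than one place, and this pair shows that the drawn configuration at this one carbon is enough to shift the number, modestly but beyond the scatter, with no atom entering or leaving. The step can be tied to that single stereocentre, and to nothing else in the molecule, because of one plain fact about the pair: the fact that compounds 1 and 4 differ only in the configuration as drawn.

This remains a single pair on a single core, so it does not show why the two arrangements differ, or whether reversing a stereocentre elsewhere in the molecule or on a different core would shift the number in the same direction. Also open, from the compounds shown here alone, is what would happen in either configuration if the group on this ring carbon gave way to an amine or a carboxylic acid.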